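A few compounds are considered here, and "the series" means these few. Any claim that something is new, unique, unknown or untested is made for them only; others in the source may bear on it.

Measured in an ADME assay for permeability, using PAMPA, with a stated time of 4 h; a higher number here means that the compound crosses the layer faster, a lower number that the compound crosses the layer more slowly:
- Compound 1 `Cn1c(COc2cccc(C(=O)O)c2)nc2ccc(Oc3ccc(Cl)c(F)c3)nc21`: 25.6 10^-6 cm/s
- Compound 2 `Cc1ccc(Oc2ccc3nc(COc4cccc(C(=O)O)c4)n(C)c3n2)cc1C`: 12.4 10^-6 cm/s
- Compound 3 `Cn1c(COc2cccc(C(=O)O)c2)nc2ccc(Oc3cccc(Cl)n3)cc21`: 7.6 10^-6 cm/s

The number for compound 3 cannot be told apart from that of compound 2 within the usual scatter, but it lies beyond the scatter under that of compound 1. Compound 4 `Cc1ccc(Oc2ccc3nc(COc4cccc(C(=O)O)c4)n(C)c3c2)nc1` differs from compound 3 in one place: 5-methylpyridin-2-yl in place of 6-chloropyridin-2-yl on an oxygen on an aromatic ring. Here 5-methylpyridin-2-yl stands in place of 6-chloropyridin-2-yl on an oxygen on an aromatic ring. One measured step offers a loose guide: a 2.1-fold lower number from compound 1 to compound 2 (0.31 log units; beyond the scatter), where 3,4-dimethylphenyl replaced 4-chloro-3-fluorophenyl on such an oxygen. Methyl took over from chloro there too, though on a different ring. A small drop in this assay is expected, probably within the scatter. The estimated change is a 1.5-fold lower number from compound 3 to compound 4 (0.18 log units; within the scatter). For compound 4 the expected value is 5 10^-6 cm/s, with an estimated range of 2.5 10^-6 cm/s to 10 10^-6 cm/s.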

Compound 4, apparent permeability: 4.8 10^-6 cm/s
For compound 4 the middle estimate is 1.0-fold (0.02 log units) above the measured one; low and high end bracket the measured number.
By their numbers in this assay, from the lowest: compounds 4, 3 and 2 (each within the scatter of the next, the first and the last beyond it); then compound 1.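

At this oxygen, 5-methylpyridin-2-yl in place of 6-chloropyridin-2-yl gives a 1.6-fold lower number from compound 3 to compound 4 (0.20 log units; within the scatter) in this assay so on this pyridine ring the two groups cannot be told apart in this read-out. The change swaps chloro for methyl and also alters the numbered ring position, so the two differences cannot be separated here. Nothing shown explains the result. The compounds shown leave open how 5-chloropyridin-2-yl or 6-methylpyridin-2-yl would compare, which would separate group from position. An amine on this ring also remains an open case.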